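Swapping a Ring Sulfonyl Group for a Hydroxyacetyl Amide

This account rests on a few compounds, and the source may have more. Where it says the series, first, only, none or still open, it means among the compounds named here.

Compound 1 `CN1CCN(c2ccc(Nc3ncc4nc(Nc5ccc(F)cc5)n([C@H]5CCCN(S(=O)(=O)C6CC6)C5)c4n3)cc2)CC1`: 1150 nM
Compound 2 `CN1CCN(c2ccc(Nc3ncc4nc(Nc5ccccc5)n([C@H]5CCN(S(=O)(=O)C6CC6)C5)c4n3)cc2)CC1`: 240 nM

In a functional assay on NCI-H1975 cells (Homo sapiens) for antiproliferative activity, read by MTT assay, with a stated time of 72 h (on this read-out lower numbers stand for stronger inhibition and higher numbers for weaker inhibition), compound 1 gives 1150 nM, the higher of the two numbers; compound 2 gives 240 nM, a gap beyond the scatter. Compound 3 `CN1CCN(c2ccc(Nc3ncc4nc(Nc5ccc(F)cc5)n([C@H]5CCCN(C(=O)CO)C5)c4n3)cc2)CC1` is not yet measured. It differs from compound 1 in one place: (hydroxymethyl)carbonyl in place of cyclopropylsulfonyl on an amine nitrogen in a ring. Going by the values given here, no measured pair shows this change alone, so the expected step is uncertain; a step no larger than the scatter is expected, in either direction. For compound 3 the estimated value is 1000 nM, with a range from 350 nM to 3000 nM, which is expected to mean a 1.2-fold lower number from compound 1 to compound 3 (0.06 log units; within the scatter).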

Compound 3, half-maximal inhibitory concentration: 750 nM
Beside the measured number, compound 3's estimate is 1.3-fold (0.12 log units) above it; measured number inside the range.
By their numbers in this assay, from the lowest: compound 2; then compounds 3 and 1 (each within the scatter of the next).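

Exchanging cyclopropylsulfonyl for (hydroxymethyl)carbonyl on this ring nitrogen gives a 1.5-fold lower number from compound 1 to compound 3 (0.19 log units; within the scatter) in this assay. The two groups therefore cannot be told apart on this read-out, even though the three-membered ring is lost and a hydrogen-bond donor is gained. Nothing measured here bears on why they read alike. On these data alone, whether a simple amine or a longer chain on this nitrogen would also read alike remains open. Compound 2 differs from both compounds in more than one place, so its lower number cannot be traced to any single change.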